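Compound 4: tetrazole in place of methylpyrazole

The compounds below may be only part of what the source reports. "The series", "measured", "known", "first", "only" and "open" are said of these compounds alone.

Compound 3 `CC(C)Oc1cc(-c2cncc(-c3cnn(C)c3)c2)ccc1C(N)=O` gives 400 nM in an assay on cells for inhibition of MAP kinase-interacting serine/threonine-protein kinase 1 (Homo sapiens), read by mobility shift assay, with stated times of 10 min and 60 min, in the presence of a further agent that is not named here (on this read-out lower numbers stand for stronger inhibition and higher numbers for weaker inhibition), the highest number among the three compounds measured. Compound 1 `CC(C)Oc1cc(-c2cncc(-c3cnn(C(C)C)c3)c2)ccc1C(N)=O` gives 85 nM and compound 2 `Cc1c(-c2cncc(-c3ccc(C(N)=O)c(OC(C)C)c3)c2)cnn1C` gives 60 nM. The steps of a 4.7-fold higher number from compound 1 to compound 3 (0.67 log units; beyond the scatter) and a 6.7-fold higher number from compound 2 to compound 3 (0.82 log units; beyond the scatter) both run toward higher numbers as alkyl is removed from the five-membered ring, whereas a 1.4-fold lower number from compound 1 to compound 2 (0.15 log units; within the scatter) stays within the scatter.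

Compound 4 `CC(C)Oc1cc(-c2cncc(-c3nn[nH]n3)c2)ccc1C(N)=O` carries the change (2H-tetrazol-5-yl in place of 1-methyl-1H-pyrazol-4-yl on an aromatic carbon). Among the measured compounds shown here, no measured step exchanges the whole ring; the only steps that bear on the change, a 4.7-fold higher number from compound 1 to compound 3 (0.67 log units; beyond the scatter) and a 6.7-fold higher number from compound 2 to compound 3 (0.82 log units; beyond the scatter), concern substituents on the ring that leaves. Because a 4.7-fold higher number from compound 1 to compound 3 (0.67 log units; beyond the scatter) and a 6.7-fold higher number from compound 2 to compound 3 (0.82 log units; beyond the scatter) both moved toward higher numbers on removal of alkyl, and compound 4 carries no alkyl on the entering ring, a step of a 2.0-fold higher number from compound 3 to compound 4 (0.30 log units; within the scatter) toward a higher number is expected, with wide uncertainty. For compound 4 the estimated value in this assay is 800 nM, within a range from 200 nM to 3200 nM.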

Compound 4, half-maximal inhibitory concentration: 310 nM
For compound 4 the middle estimate is 2.6-fold (0.41 log units) above the measured one; the measured number falls inside the stated range.
By their numbers in this assay, from the lowest: compounds 2 and 1 (each within the scatter of the next); then compounds 4 and 3 (each within the scatter of the next).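

In this assay the exchange of 1-methyl-1H-pyrazol-4-yl for 2H-tetrazol-5-yl gives a 1.3-fold lower number from compound 3 to compound 4 (0.11 log units; within the scatter) on this aromatic carbon, so the position accepts a ring with 4 hetero atoms and 1 hydrogen-bond donor without a reading separable from that of the methylpyrazole. The gap to the more heavily substituted pyrazoles persists, with a 5.2-fold higher number from compound 2 to compound 4 (0.71 log units; beyond the scatter) and a 3.6-fold higher number from compound 1 to compound 4 (0.56 log units; beyond the scatter) in the same assay, and compound 1 and compound 2 keep the lower numbers in this set. No measurement available here accounts for the tetrazole matching the methylpyrazole.

Open, as far as these compounds go, is whether a methyl or isopropyl group on the tetrazole ring would follow the steps seen on the pyrazole. Also open, from the compounds shown here alone, is how a carboxylic acid or a primary amine would read at this position.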